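The compounds below may be only part of what the source reports. "The series", "measured", "known", "first", "only" and "open" are said of these compounds alone.

Measured in a functional assay on NCI-H1975 cells (Homo sapiens) for antiproliferative activity, read by CCK-8 assay, with a stated time of 72 h; a lower number here means a stronger inhibitor of growth, a higher number a weaker inhibitor of growth:
- compound 1 `CC[C@@H]1C(=O)N(C)c2cnc(Nc3ccc(S(=O)(=O)NCCO)cc3)nc2N1C1CCCC1`: 2100 nM
- compound 2 `CCC1C(=O)N(C)c2cnc(Nc3ccc(S(=O)(=O)NCC(C)C)cc3)nc2N1c1ccn(C)n1`: 15000 nM

Compound 1 gives the lowest number of the two. Among the measured compounds shown here, compound 2 gives a higher number, and the gap to compound 1 is beyond the scatter; the two structures differ in more than one place, so the pair gives no isolated step and only its two values can be read.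

Compound 3 `CC[C@@H]1C(=O)N(C)c2cnc(Nc3ccc(S(=O)(=O)NCCCO)cc3)nc2N1C1CCCC1` is the next point to be measured. Against compound 1 it differs in one place: hydroxymethyl in place of hydroxy on a saturated chain carbon, two bonds along the chain from a sulfonamide nitrogen. For the measured compounds named here, no measured pair in the set shows the effect of a change at this position, so nothing here indicates a direction for this step. A chain of this kind lengthened by a single carbon is expected to move the number in this assay little, if at all, and the step from compound 1 is expected to stay within the scatter.

The estimate for compound 3 is therefore 2000 nM, with a range of 900 nM to 4500 nM, an expected step of a 1.1-fold lower number from compound 1 to compound 3 (0.02 log units; within the scatter).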

Compound 3, concentration for 50% growth inhibition: 2140 nM
The estimate for compound 3 lay 1.1-fold (0.03 log units) below the measured number; low and high end bracket the measured number.
By their numbers in this assay, from the lowest: compounds 1 and 3 (each within the scatter of the next); then compound 2.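

In this assay, hydroxymethyl in place of hydroxy on a saturated chain carbon, two bonds along the chain from a sulfonamide nitrogen, gives a 1.0-fold higher number from compound 1 to compound 3 (0.01 log units; within the scatter) and so stays within the scatter. Among the compounds shown here, this is the first single-place step, and at this position the 2-hydroxyethyl and 3-hydroxypropyl chains cannot be told apart in this read-out. No measurement in hand gives a reason for this result.

On these data alone, whether the same holds for a longer chain, or for an amine or a carboxylic acid in place of the hydroxy, remains open. Also open, as far as these compounds go, is whether this reading carries over when the rest of compound 1 is changed; compound 2 differs from compound 1 in more than one place and offers no such test.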